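This account rests on a few compounds, and the source may have more. Where it says the series, first, only, none or still open, it means among the compounds named here.

Measured compounds in a physicochemical assay for lipophilicity, read by HPLC, measured as chromatographic lipophilicity, at pH 7.4; on this read-out lower numbers stand for lower lipophilicity and higher numbers for higher lipophilicity:
- compound 1 `O=C(c1cnco1)N1CCC(C(=O)N2N=CC[C@H]2c2ccccc2)CC1` gives 2.7
- compound 2 `CC(C)(C)C(=O)N1CCC1c1ccccc1` gives 5
- compound 3 `O=C(c1cc[nH]n1)N1CCC(C(=O)N2N=CCC2c2ccccc2)CC1` gives 2.4

Compound 1 stands second highest of the three numbers in this assay. Its nearest neighbour is compound 3, whose value lies lower by an amount within the usual scatter, so the two are not separated. Its furthest is compound 2, whose value lies higher by a gap well beyond the scatter. Going by the values given here, no two of the measured compounds differ in a single place, so no measured step is available as a guide.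

Compound 4 `O=C(C1CCN(c2ccccc2)CC1)N1N=CC[C@H]1c1ccccc1` is the next compound to be measured in this assay. Relative to compound 1 it differs in one place:

phenyl in place of (1,3-oxazol-5-yl)carbonyl on an amine nitrogen in a ring

Among the compounds with values here, a step of this kind, with no measured counterpart in the set, is expected to move this assay upward by a sizeable amount, beyond the scatter; the expected step is a number 1.80 log units higher from compound 1 to compound 4 (beyond the scatter). Compound 4 is accordingly estimated at 4.5, in a range from 3.9 to 5.1.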

Compound 4, distribution coefficient: 6.3
Compound 4: middle estimate off by 1.80 log units, on the low side, outside the stated range (above it).
By their numbers in this assay, from the lowest: compounds 3 and 1 (each within the scatter of the next); then compound 2; then compound 4.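

In this assay the amine nitrogen of the six-membered non-aromatic ring proves to be a position where one change can shift the read-out strongly: phenyl in place of (1,3-oxazol-5-yl)carbonyl gives a number 3.60 log units higher from compound 1 to compound 4 (beyond the scatter) on the same core. Going by these compounds alone, this is the only single-place step, and the earlier compounds gave no measured reading for this position. Within the data shown here, nothing measured so far accounts for the size of the step.

Going by these compounds, it remains open how much of the step belongs to the entering phenyl and how much to the departure of the (1,3-oxazol-5-yl)carbonyl. A benzoyl, a pyridyl or a plain methyl on the same nitrogen would help to divide the step between those two parts.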